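Compound 3: 5-oxopyrrolidin-2-yl in place of methyl

This account rests on a few compounds, and the source may have more. Where it says the series, first, only, none or still open, it means among the compounds named here.

Compound 1 (`O=C(OCc1ccccc1)c1ccsc1NC(=O)[C@@H]1CCCN1`) and compound 2 (`CCOC(=O)c1ccsc1NC(=O)[C@@H]1CCCN1`) have both been read in a toxicity assay on HUVEC cells (Homo sapiens) for inhibition; a higher number here means a weaker inhibitor of growth, a lower number a stronger inhibitor of growth. Compound 1 gives > 250 ug/mL which is a limit of the assay. Compound 2 gives > 250 ug/mL which is also a limit. Compound 2 therefore stands with no number of its own: the limit of > 250 ug/mL in this assay, at which 2 of the 2 values shown sit, and nothing more can be said of its place. Compound 3 (`O=C1CC[C@@H](COC(=O)c2ccsc2NC(=O)[C@@H]2CCCN2)N1`) carries 5-oxopyrrolidin-2-yl in place of methyl on a saturated chain carbon bound to an oxygen next to a carbonyl group. Among the compounds with values here, the one measured step at this place is a step that the two limits leave unreadable from compound 1 to compound 2 so no size can be carried over, and no step beyond the scatter is expected in this assay in either direction. The expected change is a step that the limit leaves unreadable from compound 2 to compound 3 as an estimate only. For compound 3 the estimate is 280 ug/mL with 150 ug/mL to 500 ug/mL as the expected range.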

Compound 3, concentration for 50% growth inhibition: 88.6 ug/mL
The estimate for compound 3 lay 3.2-fold (0.50 log units) above the measured number; the whole stated range lies above it.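

In this assay, within the data shown here, the change at this position, on a saturated chain carbon bound to an oxygen next to a carbonyl group, gives the first readable step: an at least 2.8-fold lower number from compound 2 to compound 3 (0.45 log units; beyond the scatter), and likewise an at least 2.8-fold lower number from compound 1 to compound 3 (0.45 log units; beyond the scatter). Among these compounds, the step between the phenyl and methyl groups cannot be read, so the earlier pair showed only that neither group brings a number inside the range of this assay, whereas 5-oxopyrrolidin-2-yl does. The position can therefore respond to the group it carries, and the two earlier compounds give only a floor for the size of that response: the limit of > 250 ug/mL in this assay, at which 2 of the 3 values shown sit.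

The compounds shown leave open whether the step follows the ring, its hydrogen-bond donor or its defined stereocentre. A plain pyrrolidin-2-yl, or an amine or a carboxylic acid on a longer chain at this place, would help to separate these.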